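Amine substituent change toward an aryl-bearing chain

A few compounds are considered here, and "the series" means these few. Any claim that something is new, unique, unknown or untested is made for them only; others in the source may bear on it.

Compound 2 `COc1cc(Oc2cccc(Nc3ccccc3)c2)cc(OC)c1CNC(C)C` is measured in a functional assay on SW-620 cells (Homo sapiens) for inhibition, read by MTT assay, with a stated time of 72 h; on this read-out higher numbers stand for weaker inhibition and lower numbers for stronger inhibition. In this assay compound 2 gives > 20000 nM, which is a limit of the assay and not a number. Compound 1 `COc1cc(Oc2cccc(Nc3ccccc3)c2)cc(OC)c1CNC1CC1` differs from it only at the amine nitrogen. In this assay compound 1 gives > 20000 nM, again a limit and not a number. The step that the two limits leave unreadable from compound 1 to compound 2 therefore carries no readable size, and both values are summed up by the limit of > 20000 nM in this assay, at which 2 of the 3 values shown sit. Compound 3 `COc1ccc([C@@H](C)NCc2c(OC)cc(Oc3cccc(Nc4ccccc4)c3)c(OC)c2OC)cc1` differs from compound 2 at several places. In this assay, among the compounds with values here, compound 3 gives 8250 nM, the only number in the set.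

Compound 4 `COc1ccc(CCCNCc2c(OC)cc(Oc3cccc(Nc4ccccc4)c3)cc2OC)cc1` is not yet measured. It differs from compound 2 as follows: 3-(4-methoxyphenyl)propyl in place of isopropyl on an amine nitrogen. Within the data shown here, no measured step bears directly on this change; the single step available, from compound 1 to compound 2, is unreadable. Compound 3 shows that a compound of this series with an aryl-bearing group on the amine nitrogen can return a number rather than a limit. Compound 4 is therefore expected to give roughly 10000 nM, between 3000 nM and 30000 nM. The expected step is an at least 2.0-fold lower number from compound 2 to compound 4 (0.30 log units; that floor lies within the scatter).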

Compound 4, half-maximal inhibitory concentration: 6400 nM
Compound 4: the middle estimate sits 1.6-fold (0.19 log units) above what was measured, and the stated range covers the measured number.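

In this assay the amine nitrogen proves to be a place where a change of substituent can give a number rather than a limit: 3-(4-methoxyphenyl)propyl in place of isopropyl gives an at least 3.1-fold lower number from compound 2 to compound 4 (0.49 log units; beyond the scatter), and in place of cyclopropyl it gives an at least 3.1-fold lower number from compound 1 to compound 4 (0.49 log units; beyond the scatter). Compound 1 and compound 2, with the two small groups, each stand at a limit and not a number: the limit of > 20000 nM in this assay, at which 2 of the 4 values shown sit. Both new steps are therefore minimum sizes only, and the step between the two small groups cannot be read.

The compounds shown do not separate the contribution of the propyl chain from that of the 4-methoxyphenyl group. A plain longer alkyl chain, 3-phenylpropyl or 2-(4-methoxyphenyl)ethyl on the amine nitrogen would bear on that question.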